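Side-chain truncation at the amino-acid position

This account rests on a few compounds, and the source may have more. Where it says the series, first, only, none or still open, it means among the compounds named here.

Measured:
compound 1 `O=C(CN(c1ncnc2c1ncn2C1CCCCO1)C1CC1)N[C@@H](CCC(=O)OCc1ccccc1)C(=O)OCc1ccccc1`: 32.6%
compound 2 `NC(=O)C[C@H](NC(=O)CN(c1ncnc2c1ncn2C1CCCCO1)C1CC1)C(=O)OCc1ccccc1`: 34.5%

In a functional assay on the whole organism (Tail, strain ICR) with Mus musculus as the target, in the tail flick test, with a stated time of 30 min, at a dose of 25 umol/kg by the oral route (on this read-out higher numbers stand for a stronger effect at the one dose given and lower numbers for a weaker effect), compound 1 gives 32.6% and compound 2 gives 34.5%; the step of a number 1.9 percentage points higher from compound 1 to compound 2 (within the scatter) lies within the scatter, so the two stand together on this read-out. Compound 3 `C[C@H](NC(=O)CN(c1ncnc2c1ncn2C1CCCCO1)C1CC1)C(=O)OCc1ccccc1` differs from compound 2 by hydrogen in place of carbamoyl on a saturated chain carbon, two bonds along the chain from an amide-type nitrogen and a carbonyl carbon. Within the data shown here, the one measured step, which exchanged a side chain at this same saturated chain carbon, was a number 1.9 percentage points higher from compound 1 to compound 2 (within the scatter) and moved nothing beyond scatter; no measured step removes the group outright. For compound 3 a step of a number 1.5 percentage points lower from compound 2 to compound 3 (within the scatter) is therefore expected, none beyond the scatter. Compound 3 is estimated at 33%, ranging 18% to 48%.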

Compound 3, a percentage reported as activity, at one dose (the size of the read-out at that dose, not a potency): 55.9%
Estimate against measurement, compound 3: 22.9 percentage points below; the whole stated range lies below it.
By their numbers in this assay, from the lowest: compounds 1 and 2 (each within the scatter of the next); then compound 3.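

Here the group on this saturated chain carbon matters in this assay: carbamoylmethyl to methyl gives a number 21.4 percentage points higher from compound 2 to compound 3 (beyond the scatter) and is the first change beyond the scatter. The (benzyloxycarbonyl)methyl side chain gives way to methyl in the same sense, with a number 23.3 percentage points higher from compound 1 to compound 3 (beyond the scatter) as the step, so two different side chains that stood together both lie under methyl. Nothing measured here accounts for this.

Still open, going by these compounds, is whether an ethyl or isopropyl chain on this carbon would hold the level of compound 3 or lose it. On these data alone, an amine or a carboxylic acid at the end of a longer chain there also remains untested against methyl.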